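A Dihydroxy Side Chain on a Tetrabrominated Core

The source may report more compounds than this note shows. Statements on the series, on what has been measured and on what is new or still open speak of the compounds shown alone.

Compound 2 `CC(O)CCn1nc2c(Br)c(Br)c(Br)c(Br)c2n1` carries a 3-hydroxybutyl chain on the shared core. In a functional assay on MCF7 cells (Homo sapiens) for antiproliferative activity, read by MTT assay, with a stated time of 24 h, tested at 25 uM (on this read-out higher numbers stand for a weaker effect at the one concentration tested and lower numbers for a stronger effect), compound 2 gives 102%. For the measured compounds named here, its only measured neighbour is compound 1 `C[C@@H](O)CCn1nc2c(Br)c(Br)c(Br)c(Br)c2n1`, which in this assay gives 105%. The step of a number 3 percentage points lower from compound 1 to compound 2 (within the scatter) concerns only the drawn configuration of the hydroxyl-bearing carbon, as the fact that one of compounds 1 and 2 is drawn with a defined configuration and the other without, at the place where they differ shows, and it lies within the scatter. On the two numbers shown, compound 2 and compound 1 are therefore indistinguishable, and both sit at the end of the scale where no antiproliferative effect is seen.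

Compound 3 `OCC(O)Cn1nc2c(Br)c(Br)c(Br)c(Br)c2n1` has not been measured. It differs from compound 2 by 1,2-dihydroxyethyl in place of 2-hydroxypropyl on a saturated chain carbon bound to an aromatic nitrogen. Going by the values given here, no measured step involves a change of this kind; the single step available, a number 3 percentage points lower from compound 1 to compound 2 (within the scatter), is a stereochemical one and within the scatter, so it gives no guide to the direction a substituent change might take. With both measured values at the inactive end of the scale, compound 3 is expected to remain there, and the step of a number 2 percentage points lower from compound 2 to compound 3 (within the scatter) is expected to lie within the scatter. For compound 3 the estimate in this assay is 100%, with a range from 85% to 115%.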

Compound 3, a percentage reported as activity, at one concentration (the size of the read-out at that concentration, not a potency): 156%
Compound 3: middle estimate off by 56 percentage points, on the low side; the measured number lies above the stated range.
By their numbers in this assay, from the lowest: compounds 2 and 1 (each within the scatter of the next); then compound 3.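

In this assay, for the compounds shown here, this place on the shared core proves sensitive to the side chain: 1,2-dihydroxyethyl in place of 2-hydroxypropyl on a saturated chain carbon bound to an aromatic nitrogen gives a number 54 percentage points higher from compound 2 to compound 3 (beyond the scatter), whereas the only earlier step, a purely stereochemical one, stayed within the scatter. The same exchange gives a number 51 percentage points higher from compound 1 to compound 3 (beyond the scatter), so the shift appears whether or not the hydroxyl-bearing carbon of the parent chain is drawn with a configuration, and on this read-out it points towards the weaker effect. Going by these compounds alone, the only information at hand on these compounds concerns the drawn configuration, and it offers no explanation for this change.

Because the change from 3-hydroxybutyl to 2,3-dihydroxypropyl alters the chain and its hydroxyl groups together, the compounds shown do not separate the contribution of each. They also leave open how an amine, a carboxylic acid or a longer chain at this place would move the read-out, and whether any side chain here could bring it to the stronger-effect end of the scale.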